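Alkylamino series: cyclopentyl to methyl at the ring nitrogen

This account rests on a few compounds, and the source may have more. Where it says the series, first, only, none or still open, it means among the compounds named here.

Compound 1 `CCCCC#Cc1nc(NCC)c2ncn([C@H]3[C@H](O)[C@H](O)[C@@H]4C[C@@H]43)c2n1` is the reference of the pair. In a functional assay on CHO cells for agonist activity at adenosine receptor A3 (Homo sapiens), read by scintillation counting and cAMP accumulation, with stated times of 45 min and 15 min, in the presence of a further agent that is not named here (on this read-out higher numbers stand for an effect only at larger amounts of compound and lower numbers for an effect already at smaller amounts), compound 1 gives 15.5 nM. Compound 2 `CCCCC#Cc1nc(NC2CCCC2)c2ncn([C@H]3[C@H](O)[C@H](O)[C@@H]4C[C@@H]43)c2n1` carries cyclopentyl on the same nitrogen; in this assay compound 2 gives 27.1 nM. Among the measured compounds shown here, the one measured step, a 1.7-fold higher number from compound 1 to compound 2 (0.24 log units; within the scatter), lies within the scatter, so compound 2 stands at the highest of two numbers only nominally, and no order between compound 2 and compound 1 can be read from it.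

Compound 3 `CCCCC#Cc1nc(NC)c2ncn([C@H]3[C@H](O)[C@H](O)[C@@H]4C[C@@H]43)c2n1` is not yet measured. Its change from compound 2 is methyl in place of cyclopentyl on a nitrogen on an aromatic ring. For the measured compounds named here, the only step that bears on it is a 1.7-fold higher number from compound 1 to compound 2 (0.24 log units; within the scatter), which runs the opposite way in size of the group and stayed within the scatter. Methyl goes one step past ethyl in the same direction, so the expectation is a small step, if any, towards a lower number, and not beyond the scatter: the expected step is a 1.6-fold lower number from compound 2 to compound 3 (0.20 log units; within the scatter). Compound 3 is estimated at 17 nM in this assay, with a range from 6 nM to 45 nM.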

Compound 3, half-maximal effective concentration: 45.8 nM
Estimate against measurement, compound 3: 2.7-fold (0.43 log units) below; the whole stated range lies below it.
By their numbers in this assay, from the lowest: compounds 1, 2 and 3 (each within the scatter of the next, the first and the last beyond it).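

In this assay, among the compounds shown here, the change of ethyl to methyl on this nitrogen gives the first step at this position that lies beyond the scatter, a 3.0-fold higher number from compound 1 to compound 3 (0.47 log units; beyond the scatter), so the group here can shift the number by a modest amount even when the change is as small as hydrogen in place of methyl on the saturated chain carbon. For the compounds shown here, the exchange of cyclopentyl for methyl, a 1.7-fold higher number from compound 2 to compound 3 (0.23 log units; within the scatter), stays within the scatter, so compound 2 cannot be separated from compound 3 or from compound 1, and the three compounds give no steady trend running from methyl through ethyl to cyclopentyl, with the cyclic compound 2 being the one that prevents that reading. Nothing available here accounts for the difference between the ethyl and methyl groups at this nitrogen.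

Still open, as far as these compounds go, is whether a propyl chain, an isopropyl group or a cyclopropyl ring on this nitrogen would stay with compound 1 or move towards compound 3. Also open, from the compounds shown here alone, is how an unsubstituted amine or a benzyl group at the same place would read, and whether the modest separation of compound 1 from compound 3 holds up across a wider set of groups.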